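Fluoro in place of methyl on compound 3

The compounds below may be only part of what the source reports. "The series", "measured", "known", "first", "only" and "open" are said of these compounds alone.

Measured so far in a physicochemical assay for lipophilicity, read by HPLC; on this read-out lower numbers stand for lower lipophilicity and higher numbers for higher lipophilicity:
Compound 1 `Cc1ccsc1C(=CCCN(C)C(CCO)C(=O)NCc1ccc(F)cc1)c1sccc1C` gives 5.87
Compound 2 `Cc1ccsc1C(=CCCN(C)C(CO)C(=O)NCc1ccc(F)cc1)c1sccc1C` gives 6.45
Compound 3 `Cc1ccc(CNC(=O)C(CC(C)O)N(C)CCC=C(c2sccc2C)c2sccc2C)cc1` gives 6.15

In this assay compound 3 gives 6.15, a number within the usual scatter of the values of both compound 1 and compound 2. Compound 4 `Cc1ccsc1C(=CCCN(C)C(CC(C)O)C(=O)NCc1ccc(F)cc1)c1sccc1C` departs from compound 3 at a single place: fluoro in place of methyl on an aromatic carbon. This is fluoro in place of methyl on an aromatic carbon, para to a large group. For the measured compounds named here, only one measured step exists, the modest one a number 0.58 log units higher from compound 1 to compound 2 (beyond the scatter), which goes beyond the scatter. Going by the values given here, it is hydroxy in place of hydroxymethyl on a saturated chain carbon, so it does not touch the aromatic position, and no measured pair shows the exchange of methyl for fluoro. The nearest guide is compound 1, which also carries 4-fluorobenzyl and gives 5.87. A small downward move, not beyond the scatter, is therefore expected. The expected change is a number 0.20 log units lower from compound 3 to compound 4 (within the scatter). Compound 4 is estimated at 5.95, within an expected range of 5.6 to 6.3.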

Compound 4, partition coefficient: 5.51
Compound 4: middle estimate off by 0.44 log units, on the high side; measured number below the stated range.
By their numbers in this assay, from the lowest: compound 4; then compounds 1, 3 and 2 (each within the scatter of the next, the first and the last beyond it).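

In this assay, for the compounds shown here, the exchange of 4-methylbenzyl for 4-fluorobenzyl gives a number 0.64 log units lower from compound 3 to compound 4 (beyond the scatter) as the first measured change at this aromatic carbon, so a swap of one heavy atom here moves the number beyond the scatter. With 4-fluorobenzyl held constant, the chain also matters: 1-hydroxyethyl in place of hydroxy gives a number 0.94 log units lower from compound 2 to compound 4 (beyond the scatter) and methyl in place of hydrogen gives a number 0.36 log units lower from compound 1 to compound 4 (beyond the scatter), which leaves compound 4 lowest of the four compounds. No measurement shown accounts for the size of these steps.

The compounds shown leave open whether the exchange of methyl for fluoro keeps its size when the chain carries hydroxy or hydroxymethyl instead of 1-hydroxyethyl. They also leave open how chloro, methoxy or a nitrile would read at this aromatic carbon, and how an amine or a carboxylic acid would read on the chain.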